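Thiophene for Phenyl on Two Nucleoside Cores

The compounds below may be only part of what the source reports. "The series", "measured", "known", "first", "only" and "open" are said of these compounds alone.

In an ADME assay on MRC5 cells (Homo sapiens), read by MTT assay, with a stated time of 72 h (a higher number here means a weaker inhibitor, a lower number a stronger inhibitor), compound 1 `CSc1ncnc2c1c(-c1ccccc1)cn2[C@@H]1O[C@H](CO)[C@@H](O)[C@H]1O` gives > 100000 nM, which is a limit of the assay and not a number. Compound 2 `CSc1ncnc2c1c(-c1ccsc1)cn2[C@@H]1O[C@H](CO)[C@@H](O)[C@H]1O` gives > 100000 nM in this assay, again a limit. Between these two lies a step that the two limits leave unreadable from compound 1 to compound 2, the change being (thiophen-3-yl in place of phenyl on an aromatic carbon). Compound 3 `Nc1nc2c(c(-c3ccccc3)cn2[C@@H]2O[C@H](CO)[C@@H](O)[C@H]2O)c(=O)[nH]1` gives > 100000 nM in this assay, also a limit. The difference between the core of compound 3 and the core of compound 1 is not broken down here. Compound 4 `Nc1nc2c(c(-c3ccsc3)cn2[C@@H]2O[C@H](CO)[C@@H](O)[C@H]2O)c(=O)[nH]1` is not yet measured; it differs from compound 3 by thiophen-3-yl in place of phenyl on an aromatic carbon, the same change as from compound 1 to compound 2. Among the measured compounds shown here, every value so far sits at the limit of > 100000 nM in this assay, at which 3 of the 3 values shown sit, so compound 4 is expected to stay there too, with an expected step that the limit leaves unreadable from compound 3 to compound 4. The estimate for compound 4 in this assay is 200000 nM.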

Compound 4, half-maximal inhibitory concentration: > 100000 nM
Compound 4 gave a limit, no number; the forecaster's own chance of this, stated with the estimate: 90%; the middle value lies beyond the limit too.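

Compound 4 in this assay gives > 100000 nM, a limit and not a number, so no step can be read between compound 3 and compound 4. The compounds shown leave open whether thiophen-3-yl and phenyl differ at all here.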